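Arylamine in Place of Cyclohexylamine at the Purine Position

This account rests on a few compounds, and the source may have more. Where it says the series, first, only, none or still open, it means among the compounds named here.

Measured compounds:
compound 1 `CC(C)n1cnc2c(Nc3cccc(Cl)c3)nc(NCOCc3ccc(C(=O)Nc4ccccc4N)cc3)nc21`, 28.9%
compound 2 `Nc1ccccc1NC(=O)/C=C/c1ccc(Cn2cnc3c(NC4CCCCC4)nc(Cl)nc32)cc1`, 8.09%
compound 3 `Nc1ccccc1NC(=O)c1ccc(Cn2cnc3c(Nc4ccc(-c5ccccn5)cc4)nc(Cl)nc32)cc1`, 18.1%

In a functional assay on NCI-H460 cells (Homo sapiens) for antiproliferative activity, read by CCK-8 assay, with a stated time of 72 h, tested at 2 uM (on this read-out lower numbers stand for a weaker effect and higher numbers for a stronger effect at the one concentration tested), compound 2 gives the lowest of the three numbers. Its nearest neighbour is compound 3, a number that lies within the scatter of compound 2, so the two cannot be ordered. Compound 1 stands beyond the scatter above compound 2, so compound 1 shows a stronger effect than compound 2.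

Compound 4 `Cc1ccc(Nc2nc(Cl)nc3c2ncn3Cc2ccc(/C=C/C(=O)Nc3ccccc3N)cc2)cc1` has not been measured. It differs from compound 2 in one place: 4-methylphenyl in place of cyclohexyl on a nitrogen on an aromatic ring. Among the measured compounds shown here, no measured pair shows this change by itself, so no measured step can be carried over. Compounds 1 and 3 carry an aromatic ring on the same nitrogen and give higher numbers than compound 2, but both also differ from compound 2 elsewhere, so they give only a hint of direction.

On this basis compound 4 is expected to give 15% (range 4% to 30%), with an expected step of a number 6.9 percentage points higher from compound 2 to compound 4 (within the scatter) that may not exceed the scatter.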

Compound 4, a percentage reported as inhibition, at one concentration (the size of the read-out at that concentration, not a potency): 31.3%
Compound 4: the middle estimate sits 16.3 percentage points below what was measured; measured number outside the range, above it.
By their numbers in this assay, from the lowest: compounds 2 and 3 (each within the scatter of the next); then compounds 1 and 4 (each within the scatter of the next).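

In this assay, among the compounds shown here, 4-methylphenyl in place of cyclohexyl on a nitrogen on an aromatic ring gives a number 23.2 percentage points higher from compound 2 to compound 4 (beyond the scatter), the first reading of this change on its own. Compound 1 and compound 3 also carry an aromatic ring on this nitrogen, but they differ from compound 2 elsewhere as well, whereas this pair shows that the change from cyclohexylamino to (4-methylphenyl)amino is enough by itself to produce a modest step. Nothing available accounts for the step.

From the compounds shown here alone, whether the step belongs to the aromatic ring or to its methyl group stays open; a plain phenyl on this nitrogen would separate the two. Going by these compounds, it is also open whether the step would hold with an amine in place of the chlorine on the shared core.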